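Swapping the Dichlorophenyl for a Chlorofluorophenyl

The source may hold more compounds than are shown below. What is called first, only, known or untested is meant among the compounds shown, and "the series" means these compounds.

Of the compounds shown here, two sharing one core have been measured in an assay for displacement of a labelled ligand from melanin-concentrating hormone receptor 1 (Homo sapiens), read by fluorescence; on this read-out lower numbers stand for stronger inhibition and higher numbers for weaker inhibition. Compound 1 `COc1ccccc1-c1nc2ccccc2n1CCCN1CCC(c2cccc(NC(C)=O)c2)CC1` gives 747 nM. For the measured compounds named here, compound 2 `CC(=O)Nc1cccc(C2CCN(CCCn3c(-c4ccc(Cl)c(Cl)c4)nc4ccccc43)CC2)c1` gives 24 nM, the lowest of the two numbers; the only other number, that of compound 1, lies well above it. Going by the values given here, the single known step, a 31-fold lower number from compound 1 to compound 2 (1.49 log units; beyond the scatter), shows that the aromatic group on the shared core can shift the read-out strongly. Compound 3 `CC(=O)Nc1cccc(C2CCN(CCCn3c(-c4ccc(F)cc4Cl)nc4ccccc43)CC2)c1` is the next variation: 2-chloro-4-fluorophenyl in place of 3,4-dichlorophenyl on an aromatic carbon. The measured step bears on it only in part, since it concerns the same place but a different exchange, so the size of the new step cannot be read from it directly. Because the place proved sensitive in a 31-fold lower number from compound 1 to compound 2 (1.49 log units; beyond the scatter), the number is expected to rise by a moderate step, a 3.3-fold higher number from compound 2 to compound 3 (0.52 log units; beyond the scatter). Compound 3 is therefore estimated at 80 nM, with a range from 20 nM to 400 nM.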

Compound 3, half-maximal inhibitory concentration: 4 nM
The estimate for compound 3 lay 20-fold (1.30 log units) above the measured number; measured number outside the range, below it.
By their numbers in this assay, from the lowest: compound 3; then compound 2; then compound 1.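

In this assay this position does not reach its limit with the 3,4-dichlorophenyl group: 2-chloro-4-fluorophenyl, a group with the same count of heavy atoms, gives a 6.0-fold lower number from compound 2 to compound 3 (0.78 log units; beyond the scatter). Measured against the 2-methoxyphenyl group, the exchange at this same place gives a 190-fold lower number from compound 1 to compound 3 (2.27 log units; beyond the scatter), so the spread at this one position is wider than the first step alone showed. No measurement here explains why these aromatic groups differ.

The change from 3,4-dichlorophenyl to 2-chloro-4-fluorophenyl alters both the kind of halogen atoms and where they stand, and the compounds shown do not separate those two changes. A 2-chlorophenyl group or a 4-fluorophenyl group at this place would help to show how much each halogen contributes alone.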